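The compounds below may be only part of what the source reports. "The series", "measured", "known", "first", "only" and "open" are said of these compounds alone.

Working notes on the series. The shared core is that of compound 2, `CCC(O)CO[C@H](CC=C(C)C)C1=CC(=O)c2c(O)ccc(O)c2C1=O`. In a functional assay on DU-145 cells (Homo sapiens) for cytotoxicity, read by MTT assay (on this read-out lower numbers stand for stronger inhibition and higher numbers for weaker inhibition), compound 2 gives 16400 nM, the lowest of the two numbers available; the nearest is compound 3, `CC(C)=CC[C@@H](OC(=O)CC(C)(O)C(C)C)C1=CC(=O)c2c(O)ccc(O)c2C1=O`, which in this assay gives 16900 nM, and the step of a 1.0-fold higher number from compound 2 to compound 3 (0.01 log units; within the scatter) lies within the scatter. Compound 1, `CCCC(O)CC(=O)O[C@H](CC=C(C)C)C1=CC(=O)c2c(O)ccc(O)c2C1=O`, reaches only a limit of this assay, namely > 100000 nM. The moves an at least 6.0-fold lower number from compound 1 to compound 2 (0.78 log units; beyond the scatter) and an at least 5.9-fold lower number from compound 1 to compound 3 (0.77 log units; beyond the scatter) are beyond the scatter but known only as bounds because of the limit of > 100000 nM in this assay, at which 1 of the 3 values shown sits.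

Compound 4 is `CCCCC(C)(O)CC(=O)O[C@H](CC=C(C)C)C1=CC(=O)c2c(O)ccc(O)c2C1=O`. Its change from compound 2 is (2-hydroxy-2-methylhexyl)carbonyl in place of 2-hydroxybutyl on an oxygen on a saturated carbon. Among the measured compounds shown here, two measured steps bear on it: a 1.0-fold higher number from compound 2 to compound 3 (0.01 log units; within the scatter), where a (2-hydroxy-2,3-dimethylbutyl)carbonyl in place of 2-hydroxybutyl on the same oxygen left the number unchanged within the scatter, and an at least 5.9-fold lower number from compound 1 to compound 3 (0.77 log units; beyond the scatter), where 1-hydroxy-1,2-dimethylpropyl in place of 1-hydroxybutyl on the saturated chain carbon bound to the carbonyl carbon brought the value down from the limit. The (2-hydroxy-2-methylhexyl)carbonyl of compound 4 resembles compound 3 more than compound 1. The expected step is therefore a 1.2-fold higher number from compound 2 to compound 4 (0.06 log units; within the scatter), none beyond the scatter. Compound 4 is estimated at 19000 nM in this assay, within 7000 nM to 60000 nM.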

Compound 4, half-maximal inhibitory concentration: 76500 nM
Beside the measured number, compound 4's estimate is 4.0-fold (0.60 log units) below it; measured number outside the range, above it.
By their numbers in this assay, from the lowest: compounds 2 and 3 (each within the scatter of the next); then compound 4. At a limit, above all of these: compound 1.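

On the oxygen on a saturated carbon, the enlarged group does not always leave the number in place: in this assay the change gives a 4.7-fold higher number from compound 2 to compound 4 (0.67 log units; beyond the scatter), whereas the earlier exchange at this oxygen gave a 1.0-fold higher number from compound 2 to compound 3 (0.01 log units; within the scatter). The two carbonyl-linked compounds also isolate a smaller change, as butyl in place of isopropyl on the saturated chain carbon bound to an oxygen on a saturated carbon and two saturated chain carbons gives a 4.5-fold higher number from compound 3 to compound 4 (0.66 log units; beyond the scatter), so the number here depends on the alkyl group carried by that carbon and not only on the presence of the carbonyl-linked side chain. The comparison with compound 1 rests on a limit and cannot be read as a real difference, an at least 1.3-fold lower number from compound 1 to compound 4 (0.11 log units; that floor lies within the scatter): the limit of > 100000 nM in this assay, at which 1 of the 4 values shown sits.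

On these data alone, compound 2 and compound 4 differ in the carbonyl and in the chain at once, and the share of each in their step remains open. Only isopropyl and butyl are compared on that saturated chain carbon, leaving open whether a longer chain such as hexyl would raise the number further and what a phenyl ring or a terminal amine there would give.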